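Swapping the Aryl Group on an Imine-Linked Amide

The compounds below may be only part of what the source reports. "The series", "measured", "known", "first", "only" and "open" are said of these compounds alone.

Measured so far:
Compound 1, `CCCCCCCCCCCCCCNC(=O)[C@H](CO)/N=C/c1cccc([N+](=O)[O-])c1`: 104000 nM
Compound 2, `CCCCCCCCCCCCCCNC(=O)[C@H](CO)/N=C/c1ccc(OC)cc1`: 28100 nM

Of the compounds shown here, two have been tested in a functional assay on cells (Homo sapiens) for cytotoxicity, read by MTT assay, with a stated time of 24 h; a higher number here means a weaker inhibitor, a lower number a stronger inhibitor. Compound 1 gives 104000 nM, and compound 2 gives 28100 nM. The two differ only in the group attached to the carbon carrying the double bond to nitrogen, and the change produced a 3.7-fold lower number from compound 1 to compound 2 (0.57 log units; beyond the scatter). Among the compounds with values here, on these two numbers, compound 2 stands at the lower end, with compound 1 as its only neighbour.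

Compound 3, `CCCCCCCCCCCCCCNC(=O)[C@H](CO)/N=C/c1ccccc1C`, has not yet been measured in this assay. Its change from compound 2 is 2-methylphenyl in place of 4-methoxyphenyl on a carbon with a double bond to nitrogen. Within the data shown here, no measured step exchanges a methoxyphenyl for a methylphenyl, so the single step from compound 1 to compound 2 bears on it only loosely: it shows that this position can move the number by a modest amount, without indicating which way a methyl-bearing ring would go. The expectation is therefore a step of no more than modest size, leaning towards a slightly higher number, a 1.2-fold higher number from compound 2 to compound 3 (0.10 log units; within the scatter). Compound 3 is estimated at 35000 nM, with a range from 15000 nM to 80000 nM.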

Compound 3, half-maximal inhibitory concentration: 87700 nM
Compound 3: middle estimate off by 2.5-fold (0.40 log units), on the low side; the measured number lies above the stated range.
By their numbers in this assay, from the lowest: compound 2; then compounds 3 and 1 (each within the scatter of the next).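

In this assay, the group on a carbon with a double bond to nitrogen now has three entries, and the 4-methoxyphenyl of compound 2 stands apart from the other two: the change to 2-methylphenyl gives a 3.1-fold higher number from compound 2 to compound 3 (0.49 log units; beyond the scatter). The 2-methylphenyl and 3-nitrophenyl groups cannot be told apart here, with a 1.2-fold lower number from compound 1 to compound 3 (0.07 log units; within the scatter), so two differently substituted rings give matching results, while compound 2 is the strongest inhibitor of the three. Nothing available here accounts for this difference.

The 4-methoxyphenyl and 2-methylphenyl groups differ both in the group on the ring and in its numbered place, so these compounds cannot show which of the two changes matters; a 4-methylphenyl or a 2-methoxyphenyl group would separate them. Also open, from the compounds shown here alone, is how far the number would move with an amine on the ring, or with a longer chain on the amide nitrogen.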